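The source may report more compounds than this note shows. Statements on the series, on what has been measured and on what is new or still open speak of the compounds shown alone.

The study concerns an assay on isolated protein for inhibition of malate dehydrogenase, mitochondrial (Sus scrofa), with stated times of 45 min and 30 min; on this read-out lower numbers stand for stronger inhibition and higher numbers for weaker inhibition. Compound 1, `Cc1ccc(S(=O)(=O)Nc2ccc3oc(-c4ccccc4)nc3c2)cc1`, reaches only a limit of this assay, > 63000 nM. Compound 2, `O=S(=O)(Nc1ccc(-c2nc3ccccc3o2)cc1)c1cccc(Cl)c1`, likewise gives in this assay no number but a limit, > 63000 nM. For the measured compounds named here, compound 2 therefore stands at the limit of > 63000 nM in this assay, at which 2 of the 2 values shown sit, so neither measured compound shows inhibition within the tested range, and no step between measured compounds can be sized from these two limits. Compound 3, `O=S(=O)(Nc1ccc(-c2nc3ccccc3o2)cc1)c1ccc(O)cc1`, differs from compound 2 by a single change: 4-hydroxyphenyl in place of 3-chlorophenyl on a sulfonyl sulfur. With both known values sitting at the limit, nothing in the data supports expecting a large move in either direction; the step expected here, a step that the limit leaves unreadable from compound 2 to compound 3, is none beyond the scatter. Compound 3 is accordingly estimated at 80000 nM, within a range from 20000 nM to 300000 nM, and it is expected most likely to be reported again only as a limit.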

Compound 3, half-maximal inhibitory concentration: > 63000 nM
Compound 3 ended at the assay's limit (the forecaster's own chance of this, stated with the estimate: 85%); the middle value lies beyond the limit too.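

In this assay compound 2 and compound 3 both end at a limit rather than a number, and no step can be read between them: the limit of > 63000 nM in this assay, at which 3 of the 3 values shown sit. The compounds shown leave open whether any change on the sulfonyl sulfur or the shared core can bring inhibition in this assay within the tested range.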